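This account rests on a few compounds, and the source may have more. Where it says the series, first, only, none or still open, it means among the compounds named here.

Measured compounds in a physicochemical assay for solubility, measured as kinetic solubility, at pH 2; a higher number here means a more soluble compound, a lower number a less soluble compound:
compound 1, `CC(C)C(c1ccc(-c2ccc3cccc(F)c3c2)[nH]c1=O)N1CCCCC1=O`, gives 23500 nM
compound 2, `CCn1ncc2c(F)cc(-c3ccc(C(CC)(CC)c4nnc(C)[nH]4)c(=O)[nH]3)cc21`, gives 33900 nM

Compound 1 holds the lower of the two numbers in this assay, but its nearest neighbour is compound 2, whose number lies within the usual scatter of that of compound 1, so the two cannot be told apart on this assay. The account now turns from compound 1 to compound 3, `CC(C)C(c1ccc(-c2ccc3cccc(F)c3c2)[nH]c1=O)N1CCN/C1=N\C#N`, which has not been measured. The change between them is a group of 8 heavy atoms (4 carbon, 4 nitrogen; one five-membered non-aromatic ring with 2 hetero atoms) in place of a group of 7 heavy atoms (5 carbon, 1 nitrogen, 1 oxygen; one six-membered non-aromatic ring with 1 hetero atom), on a saturated chain carbon bound to an aromatic carbon and a saturated chain carbon. Going by the values given here, compound 2 differs from compound 1 in several places at once, so no single step is available to guide the expectation; what is known is only that both measured compounds fall close together in this assay. With nothing to point in either direction, the step from compound 1 to compound 3 is expected to be small, a 1.3-fold higher number from compound 1 to compound 3 (0.11 log units; within the scatter), and not clearly beyond the scatter. Compound 3 is therefore estimated at 30000 nM in this assay, within a range of 10000 nM to 90000 nM.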

Compound 3, solubility: 32500 nM
The estimate for compound 3 lay 1.1-fold (0.03 log units) below the measured number; low and high end bracket the measured number.
By their numbers in this assay, from the lowest: compounds 1, 3 and 2 (each within the scatter of the next).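

In this assay, placing the five-membered non-aromatic ring with 2 hetero atoms where the 2-oxopiperidin-1-yl group stood gives a 1.4-fold higher number from compound 1 to compound 3 (0.14 log units; within the scatter), the first single-place step available at this position. On this saturated chain carbon bound to an aromatic carbon and a saturated chain carbon, the two groups differ in ring size, in their hetero atoms and in their hydrogen-bond donors and acceptors, yet the two compounds cannot be told apart in this pair, and the step says nothing of any other position on the shared core. No supporting data bear on this result, so it stands as an observation about this one pair alone.

Going by these compounds, whether a different kind of group at this same carbon, such as a primary amine or a carboxylic acid, would give a step beyond the scatter in this assay remains open. Also open, on these data alone, is whether a longer chain on that carbon, or a single change elsewhere on the shared core, would separate a compound from this close-lying set.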